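A few compounds are considered here, and "the series" means these few. Any claim that something is new, unique, unknown or untested is made for them only; others in the source may bear on it.

Measured in a functional assay on HCT-116 cells (Homo sapiens) for antiproliferative activity, read by MTT assay, with a stated time of 24 h; on this read-out lower numbers stand for stronger inhibition and higher numbers for weaker inhibition:
- compound 1 `COc1cc(OC)c(-c2coc3cc(OCC=C(C)C)ccc3c2=O)cc1OC`: 680 nM
- compound 2 `COc1cc(OC)c(-c2coc3cc(OCc4ccc(C#N)cc4)ccc3c2=O)cc1OC`: 4220 nM
- compound 3 `COc1cc(OC)c(-c2coc3cc(OCc4ccccc4C#N)ccc3c2=O)cc1OC`: > 10000 nM (a limit of the assay, not a number)

Compound 3 stands at the weak end of this short series, and it has only a limit. Compound 4 `COc1cc(OC)c(-c2coc3cc(OCc4ccccc4Br)ccc3c2=O)cc1OC` carries bromo in place of cyano on an aromatic carbon, ortho to a large group: bromo in place of cyano on an aromatic carbon.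

Within the data shown here, no measured step makes this exchange, so the evidence is indirect. The nearest step is an at least 2.3-fold higher number from compound 2 to compound 3 (0.37 log units; beyond the scatter), which keeps the cyano group and is at least modest. The other two steps are a 6.2-fold higher number from compound 1 to compound 2 (0.79 log units; beyond the scatter), which is modest, and an at least 14-fold higher number from compound 1 to compound 3 (1.16 log units; beyond the scatter), which is large. Together they show that this assay responds to changes in this part of the molecule. A modest move towards a lower number is therefore expected, with a second reading at the limit still quite possible.

The estimated change is an at least 1.6-fold lower number from compound 3 to compound 4 (0.22 log units; that floor lies within the scatter). For compound 4 the expected value is 6000 nM, with an estimated range of 2000 nM to 15000 nM.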

Compound 4, half-maximal inhibitory concentration: 4550 nM
The estimate for compound 4 lay 1.3-fold (0.12 log units) above the measured number; low and high end bracket the measured number.
By their numbers in this assay, from the lowest: compound 1; then compounds 2 and 4 (each within the scatter of the next). At a limit, above all of these: compound 3.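

In this assay, bromo in place of cyano on this aromatic carbon, ortho to a large group, gives an at least 2.1-fold lower number from compound 3 to compound 4 (0.34 log units; beyond the scatter), so the group at this place, and not only its position on the ring, affects the reading. The 2-bromophenyl and 4-cyanophenyl groups cannot be told apart, with a 1.1-fold higher number from compound 2 to compound 4 (0.03 log units; within the scatter), while the 2-methylprop-1-en-1-yl group keeps its advantage, with a 6.7-fold higher number from compound 1 to compound 4 (0.83 log units; beyond the scatter). Compound 3 has only a limit of the assay, so the first step is a floor and not a size: the limit of > 10000 nM in this assay, at which 1 of the 4 values shown sits.

On these data alone, it stays open whether a methoxy group, an amine or a fluoro group on the same aromatic carbon would give a number nearer that of compound 1. The compounds also leave open how bromo would read on the ring position that cyano holds in compound 2.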